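This account rests on a few compounds, and the source may have more. Where it says the series, first, only, none or still open, it means among the compounds named here.

compound 1 `COc1cc(C(=O)c2sc(-c3ccccc3)cc2N)cc(OC)c1OC`: 11 nM
compound 2 `COc1cc(C(=O)c2sc(-c3ccncc3)cc2N)cc(OC)c1OC`: 1810 nM

In a functional assay on L1210 cells (Mus musculus) for antiproliferative activity (a lower number here means a stronger inhibitor, a higher number a weaker inhibitor), compound 2 has the higher number of the pair. Compound 3 `COc1cc(C(=O)c2sc(-c3ccc(C)cc3)cc2N)cc(OC)c1OC` differs from compound 2 as follows: 4-methylphenyl in place of pyridin-4-yl on an aromatic carbon. Among the measured compounds shown here, this restores a ring of carbon only, now with a methyl group that no measured compound carries. For the measured compounds named here, the one measured step bearing on this is the large 160-fold higher number from compound 1 to compound 2 (2.22 log units; beyond the scatter), which had pyridin-4-yl in place of phenyl. A large reversal towards a lower number in this assay is therefore expected, giving the estimated 91-fold lower number from compound 2 to compound 3 (1.96 log units; beyond the scatter). Compound 3 is estimated at 20 nM, within an expected range of 5 nM to 90 nM.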

Compound 3, half-maximal inhibitory concentration: 18 nM
The estimate for compound 3 lay 1.1-fold (0.05 log units) above the measured number; the range from low to high includes it.
By their numbers in this assay, from the lowest: compounds 1 and 3 (each within the scatter of the next); then compound 2.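

In this assay, 4-methylphenyl on the aromatic carbon next to the ring sulfur recovers what pyridin-4-yl lost, giving a 100-fold lower number from compound 2 to compound 3 (2.00 log units; beyond the scatter). The added methyl makes no readable difference, with a 1.6-fold higher number from compound 1 to compound 3 (0.21 log units; within the scatter), so this position accepts more than an unsubstituted phenyl ring. No measurement available here accounts for the difference between these rings.

As far as these compounds go, whether methoxy, chlorine or a longer chain such as ethyl on the phenyl ring would behave like methyl remains open. So does whether pyridin-3-yl would follow pyridin-4-yl.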